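Moving the fluorine from one ring position to another

The source may report more compounds than this note shows. Statements on the series, on what has been measured and on what is new or still open speak of the compounds shown alone.

Measured so far in a functional assay on CHO cells for agonist activity at adenosine receptor A1 (Homo sapiens), read by fluorescence and ERK phosphorylation, with stated times of 30 min and 1.5 h, tested at 10 uM; a higher number here means a stronger effect of the compound at the concentration tested, a lower number a weaker effect:
- compound 1 `Nc1scc(-c2ccccc2)c1C(=O)c1ccccc1`: 48%
- compound 2 `Nc1scc(-c2ccccc2F)c1C(=O)c1ccccc1`: 68%
- compound 3 `Nc1scc(-c2cccc(F)c2)c1C(=O)c1ccccc1`: 52%

Compound 3 stands second highest of the three. Its nearest neighbour is compound 1, and the two differ by a number 4 percentage points higher from compound 1 to compound 3 (within the scatter), which is within the scatter. Compound 2 is furthest from it, with a number 16 percentage points lower from compound 2 to compound 3 (beyond the scatter) separating them, a modest step beyond the scatter.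

Compound 4 `Nc1scc(-c2ccc(F)cc2)c1C(=O)c1ccccc1` has the same atoms as compound 3, joined differently: 4-fluorophenyl in place of 3-fluorophenyl on an aromatic carbon. The shared core and the benzoyl group are untouched; only the fluorine on the phenyl ring moves.

For the measured compounds named here, two measured steps bear on this. Adding fluorine to give 2-fluorophenyl gave a number 20 percentage points higher from compound 1 to compound 2 (beyond the scatter), while adding it to give 3-fluorophenyl gave only a number 4 percentage points higher from compound 1 to compound 3 (within the scatter). So the position of the fluorine matters: one placement helped modestly, the other did nothing beyond the scatter. Nothing measured tells how the 4-fluorophenyl placement will behave, so the expectation is cautious: a step in this assay of about no change at the digits printed from compound 3 to compound 4 (within the scatter), that is, no change beyond the scatter, with a wide margin either way.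

Compound 4 is therefore expected to give 52%, within a range of 38% to 66%.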

Compound 4, a percentage reported as activity, at one concentration (the size of the read-out at that concentration, not a potency): 60%
For compound 4 the middle estimate is 8 percentage points below the measured one; low and high end bracket the measured number.
By their numbers in this assay, from the lowest: compounds 1, 3, 4 and 2 (each within the scatter of the next, the first and the last beyond it).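

The step to 4-fluorophenyl gives a number 8 percentage points higher from compound 3 to compound 4 (within the scatter) and a number 8 percentage points lower from compound 2 to compound 4 (within the scatter) in this assay so this placement cannot be told apart from either of the other two fluorinated phenyl groups. Set against the plain phenyl group, the same placement gives a number 12 percentage points higher from compound 1 to compound 4 (beyond the scatter) which makes it the second fluorine position, after 2-fluorophenyl, to clear the scatter, whereas 3-fluorophenyl does not. The effect of moving the fluorine therefore looks less like an on-off switch than an overlapping set, in which only 2-fluorophenyl and 3-fluorophenyl stand clearly apart and 4-fluorophenyl cannot be separated from either.

No measurement at hand accounts for the differences between these placements. As far as these compounds go, it also stays open whether chlorine, a methoxy group or a second fluorine on this phenyl group would behave like the single fluorine, and what a change to the benzoyl group or the amino group would do.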